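A few compounds are considered here, and "the series" means these few. Any claim that something is new, unique, unknown or untested is made for them only; others in the source may bear on it.

Compound 3 `CC#C[C@H]1CN(S(=O)(=O)c2ccc(N)nc2)CCN1c1ccc(C(O)(COC)C(F)(F)F)cc1` gives 202 nM in an assay on cells (Hepatocyte) for inhibition of glucokinase regulatory protein (Mus musculus), with stated times of 20 min and 40 min (on this read-out higher numbers stand for an effect only at larger amounts of compound and lower numbers for an effect already at smaller amounts), the highest number among the three compounds measured. Compound 1 `CC#C[C@H]1CN(S(=O)(=O)c2ccc(N)nc2)CCN1c1ccc([C@@](O)(CO)C(F)(F)F)cc1` gives 89 nM in this assay, and compound 2 `CC#C[C@H]1CN(S(=O)(=O)c2ccc(N)nc2)CCN1c1ccc(S(N)(=O)=O)cc1` gives 37 nM. The steps run a 2.3-fold higher number from compound 1 to compound 3 (0.36 log units; beyond the scatter) and a 5.5-fold higher number from compound 2 to compound 3 (0.74 log units; beyond the scatter), while a 2.4-fold lower number from compound 1 to compound 2 (0.38 log units; beyond the scatter) separates the two lower numbers.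

Compound 4 `CC#CCC(O)(c1ccc(N2CCN(S(=O)(=O)c3ccc(N)nc3)C[C@@H]2C#CC)cc1)C(F)(F)F` differs from compound 3 by prop-1-yn-1-yl in place of methoxy on a saturated chain carbon, two bonds along the chain from an aromatic carbon and an oxygen on a saturated carbon. Among the compounds with values here, only one measured step touches this same region of the molecule: a 2.3-fold higher number from compound 1 to compound 3 (0.36 log units; beyond the scatter), where the group on the saturated chain carbon was altered and the number rose modestly. Within the data shown here, no measured step involves a prop-1-yn-1-yl group or a but-2-yn-1-yl chain, so the outcome of this assay for compound 4 rests on little. Because a 2.3-fold higher number from compound 1 to compound 3 (0.36 log units; beyond the scatter) was only modest, the larger change now made at the same position is expected to move the number by a similar or somewhat greater amount upward. Compound 4 is therefore expected to give 280 nM in this assay, within 100 nM to 800 nM, an expected step of a 1.4-fold higher number from compound 3 to compound 4 (0.14 log units; within the scatter).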

Compound 4, half-maximal effective concentration: 137 nM
The estimate for compound 4 lay 2.0-fold (0.31 log units) above the measured number; low and high end bracket the measured number.
By their numbers in this assay, from the lowest: compound 2; then compounds 1, 4 and 3 (each within the scatter of the next, the first and the last beyond it).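

In this assay, the step with prop-1-yn-1-yl in place of methoxy on the saturated chain carbon is a 1.5-fold lower number from compound 3 to compound 4 (0.17 log units; within the scatter), so this position accepts a but-2-yn-1-yl chain in place of methoxymethyl without a shift that can be told from the scatter. The comparison with the hydroxymethyl-bearing compound reads a 1.5-fold higher number from compound 1 to compound 4 (0.19 log units; within the scatter), which also stays within the scatter, so the three chains tried so far at this carbon cannot be clearly separated by way of compound 4. Yet a 3.7-fold higher number from compound 2 to compound 4 (0.57 log units; beyond the scatter) lies beyond the scatter, so this new chain does not close the gap to the group on the aromatic carbon in compound 2, and nothing available accounts for these results.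

The compounds shown leave open how an amine, a carboxylic acid or a longer chain at this carbon would read in this assay. They also leave open whether a chain with a ring at its end would stay within the same range.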